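From chloro to methoxy in compound 3

This account rests on a few compounds, and the source may have more. Where it says the series, first, only, none or still open, it means among the compounds named here.

Compound 1 `COc1ccccc1-c1c(C(=O)c2cc(OC)c(OC)c(OC)c2)sc2ccccc12`: 3400 nM
Compound 2 `CCOc1ccc(-c2c(C(=O)c3cc(OC)c(OC)c(OC)c3)sc3ccccc23)cc1`: 3100 nM
Compound 3 `COc1cc(C(=O)c2sc3ccccc3c2Nc2ccc(Cl)cc2)cc(OC)c1OC`: 1100 nM

In a functional assay on K562 cells (Homo sapiens) for antiproliferative activity, read by MTT assay, with a stated time of 72 h (on this read-out higher numbers stand for weaker inhibition and lower numbers for stronger inhibition), compound 3 gives the lowest of the three numbers, 1100 nM, and the other two lie beyond the scatter from it. Compound 4 `COc1ccc(Nc2c(C(=O)c3cc(OC)c(OC)c(OC)c3)sc3ccccc23)cc1` differs from compound 3 by one change: methoxy in place of chloro on an aromatic carbon. Among the measured compounds shown here, no measured step makes this exchange. The steps of a 3.1-fold lower number from compound 1 to compound 3 (0.49 log units; beyond the scatter) and a 2.8-fold lower number from compound 2 to compound 3 (0.45 log units; beyond the scatter) were modest, but each exchanges the whole group on the aromatic carbon. The step of a 1.1-fold lower number from compound 1 to compound 2 (0.04 log units; within the scatter), which exchanges one substituted phenyl for another, stayed within the scatter. A similarly small change is therefore expected in this assay, with no firm direction. The expected change is a 1.2-fold lower number from compound 3 to compound 4 (0.09 log units; within the scatter). Compound 4 is estimated at 900 nM, with an expected range of 200 nM to 3000 nM.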

Compound 4, half-maximal inhibitory concentration: 2900 nM
Compound 4: middle estimate off by 3.2-fold (0.51 log units), on the low side, within the range that was stated.
By their numbers in this assay, from the lowest: compound 3; then compounds 4, 2 and 1 (each within the scatter of the next).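

In this assay, the group para to a large group on the aromatic ring proves to count: methoxy in place of chloro gives a 2.6-fold higher number from compound 3 to compound 4 (0.42 log units; beyond the scatter), a modest step from one small exchange. The amino link alone does not set compound 3 apart, since a 1.1-fold lower number from compound 2 to compound 4 (0.03 log units; within the scatter) and a 1.2-fold lower number from compound 1 to compound 4 (0.07 log units; within the scatter) both stay within the scatter. Nothing measured here explains the chloro result. Still open, going by these compounds, is whether fluoro, methyl or a dimethylamino group at this place would track chloro or methoxy.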